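The source may hold more compounds than are shown below. What is called first, only, known or untested is meant among the compounds shown, and "the series" means these compounds.

In a functional assay on the whole organism for antagonist activity, with Mus musculus as the target, in the maximal electroshock model (a higher number here means that more compound is needed for the effect, a lower number that less compound is needed), compound 1 `Cn1nc(-c2ccccc2)nc1S(C)(=O)=O`, which carries methylsulfonyl, gives > 200 mg/kg, a limit of the assay and not a number. Compound 2 `CSc1nc(-c2ccc(Cl)cc2)nn1C` gives > 200 mg/kg, also only a limit. Compound 2 therefore sits at the limit of > 200 mg/kg in this assay, at which 2 of the 2 values shown sit, with no number to start from. Compound 3 `Cn1nc(-c2ccc(Cl)cc2)nc1S(C)(=O)=O` has methylsulfonyl in place of methylsulfanyl on an aromatic carbon. Within the data shown here, no measured step guides this change, so only a small shift toward a lower dose is expected in this assay, and the estimated change is an at least 1.3-fold lower number from compound 2 to compound 3 (0.12 log units; that floor lies within the scatter). For compound 3, the estimated dose is 150 mg/kg, with an expected range of 50 mg/kg to 300 mg/kg.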

Compound 3, dose for half-maximal effect: > 200 mg/kg
Compound 3 ended at the assay's limit; the forecaster's own chance of this, stated with the estimate: 55%; middle value at least 1.3-fold (0.12 log units) away from the limit.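

No step can be read among compound 1, compound 2 and compound 3, whose values are limits and not numbers: the limit of > 200 mg/kg in this assay, at which 3 of the 3 values shown sit.

The compounds shown leave open whether methylsulfonyl or chloro shifts the dose in this assay at all.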